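This account rests on a few compounds, and the source may have more. Where it says the series, first, only, none or still open, it means among the compounds named here.

The measured compounds:
compound 1, `CCOc1ccc(/C=N/NC(=O)COc2cccc3ccccc23)cc1O`, 18.1 ug/mL
compound 2, `O=C(COc1cccc2ccccc12)N/N=C/c1ccc(Cl)cc1`, 100 ug/mL
compound 3, `O=C(COc1cccc2ccccc12)N/N=C/c1ccc(O)cc1`, 60.6 ug/mL

All three numbers come from an ADME assay on HEL cells (Homo sapiens) for cytotoxicity; a lower number here means that less compound is tolerated, a higher number that more compound is tolerated. Compound 3 stands second highest of the three: its nearest neighbour is compound 2, reached through a 1.7-fold lower number from compound 2 to compound 3 (0.22 log units; within the scatter), while compound 1 lies furthest away, with a lower number beyond the scatter.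

Compound 4, `O=C(COc1cccc2ccccc12)N/N=C/c1cccc(O)c1`, differs from compound 3 by 3-hydroxyphenyl in place of 4-hydroxyphenyl on a carbon with a double bond to nitrogen. Within the data shown here, no measured pair shows such a move of the hydroxy group around the ring; the only measured step exchanges one group for another and stayed within the scatter. With nothing pointing either way, no step beyond the scatter is expected in this assay.

Compound 4 is therefore estimated at about 60 ug/mL, between 30 ug/mL and 120 ug/mL. This estimate corresponds to an expected step of a 1.0-fold lower number from compound 3 to compound 4 (0.00 log units; within the scatter).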

Compound 4, half-maximal cytotoxic concentration: 62.7 ug/mL
Compound 4: the middle estimate sits 1.0-fold (0.02 log units) below what was measured; the range from low to high includes it.
By their numbers in this assay, from the lowest: compound 1; then compounds 3, 4 and 2 (each within the scatter of the next).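

In this assay, moving the hydroxy group around the ring barely registers, with a 1.0-fold higher number from compound 3 to compound 4 (0.01 log units; within the scatter), so this position tolerates the shift in these two compounds. Among these compounds, the exchange of 4-chlorophenyl for 3-hydroxyphenyl is similarly small, with a 1.6-fold lower number from compound 2 to compound 4 (0.20 log units; within the scatter), whereas the loss of the ethoxy group gives the first single change to pass the scatter, with a 3.5-fold higher number from compound 1 to compound 4 (0.54 log units; beyond the scatter), and so marks that ring substituent as the one that matters here. No measurement shown accounts for these differences. 

As far as these compounds go, whether an amine or a carboxylic acid on this ring would shift the number remains open. So does whether a longer chain in place of ethoxy would go further than the ethoxy group itself.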